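The source may report more compounds than this note shows. Statements on the series, on what has been measured and on what is new or still open speak of the compounds shown alone.

Of the compounds shown here, three of the same general type have been measured so far. Compound 1, with the structure `O=C1N=C(N2CCOCC2)CN1c1ccc(Cl)cc1`, gives 1.5 in a physicochemical assay for lipophilicity; a higher number here means a more lipophilic compound, a lower number a more polar compound. Compound 2, with the structure `O=C1N=C(N2CCOCC2)CN1Cc1ccccc1`, gives 0.5 in this assay. Compound 3, with the structure `O=C1N=C(N2CCOCC2)CN1Cc1ccccc1Cl`, gives 1 in this assay. Compound 1 thus stands highest of the three. How the core of compound 1 differs from the core of compound 2 is not broken down here.

Between compound 2 and compound 3 there is a single counted difference, (chloro in place of hydrogen on an aromatic carbon), and this change produced a step of a number 0.50 log units higher from compound 2 to compound 3 (beyond the scatter).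

Compound 4, with the structure `O=C1N=C(N2CCOCC2)CN1c1ccc(Cl)c(Cl)c1`, has not yet been measured in this assay. It differs from compound 1 by chloro in place of hydrogen on an aromatic carbon. For the measured compounds named here, this is the same kind of change as the one from compound 2 to compound 3, though not the same: in compound 3 the entering chloro sits ortho to a large group, whereas in compound 4 it sits ortho to a chloro group and meta to a large group.

An upward step is expected for compound 4, of about a number 0.60 log units higher from compound 1 to compound 4 (beyond the scatter), resting on the step of a number 0.50 log units higher from compound 2 to compound 3 (beyond the scatter) that the same kind of change gave between those two compounds. On that basis the value of compound 4 in this assay is estimated at 2.1, with a likely range from 1.7 to 2.5.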

Compound 4, partition coefficient: 1.9
Compound 4: middle estimate off by 0.20 log units, on the high side; the measured number falls inside the stated range.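

Chloro in place of hydrogen on an aromatic carbon has now been read on two different cores, and in this assay the change gives a number 0.40 log units higher from compound 1 to compound 4 (beyond the scatter) on one, against a number 0.50 log units higher from compound 2 to compound 3 (beyond the scatter) on the other, so on these two pairs the step goes the same way, is modest each time and lies beyond the scatter. For the compounds shown here, this shows that the upward direction of the change held when it was carried from the core of compound 2 to the core of compound 1, but two pairs are too few to establish a rule for the series, and they do not isolate the core as a variable: in compound 4 the entering chloro stands ortho to a chloro group and meta to a large group, a different place from the one it takes in compound 3, so core and position change together. No measurement offered here accounts for the size of either step.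

What a fluoro group, a methoxy group, an amine or a carboxylic acid would do in place of that hydrogen stays open, since chloro is the only entering group among the compounds shown. Going by these compounds, whether the step would recur on a third core, or with chloro at other places on these two cores, also stays open.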